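The source may hold more compounds than are shown below. What is called first, only, known or untested is meant among the compounds shown, and "the series" means these compounds.

Series notes. Two compounds carry numbers in a functional assay on K562 cells (Homo sapiens) for cytotoxicity, read by sulforhodamine B assay, with a stated time of 48 h, tested at 100 uM; on this read-out higher numbers stand for a weaker effect at the one concentration tested and lower numbers for a stronger effect. Compound 1 `COc1ccc(-c2cc(/C=C/C(=O)c3ccc(OC)c(OC)c3)[nH]n2)cc1` gives -26% in this assay. Among the measured compounds shown here, compound 2 `COc1cc(-c2cc(/C=C/C(=O)c3ccc(Cl)c(Cl)c3)[nH]n2)cc(OC)c1OC` gives -7% in this assay, the higher of the two numbers, and the gap to compound 1 lies beyond the scatter, so at the single concentration tested compound 2 shows the weaker effect of the pair. Compound 1 and compound 2 differ in more than one place, so no single change can be tied to that gap.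

Compound 3 `COc1cc(-c2cc(/C=C/C(=O)c3ccc(F)c(F)c3)[nH]n2)cc(OC)c1OC` has not yet been measured. It differs from compound 2 in one place: 3,4-difluorophenyl in place of 3,4-dichlorophenyl on a carbonyl carbon. For the measured compounds named here, no measured pair in this set shows what such an exchange does here, so the step is expected to be small, around the scatter, with no clear direction; the expected step is a number 4 percentage points higher from compound 2 to compound 3 (within the scatter). Compound 3 is estimated at -3% in this assay, in a range from -25% to 18%.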

Compound 3, a percentage reported as activity, at one concentration (the size of the read-out at that concentration, not a potency): -7%
Estimate against measurement, compound 3: 4 percentage points above; low and high end bracket the measured number.
By their numbers in this assay, from the lowest: compound 1; then compounds 2 and 3 (each within the scatter of the next).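

In this assay, among the compounds shown here, 3,4-difluorophenyl in place of 3,4-dichlorophenyl on a carbonyl carbon gives no change at the digits printed from compound 2 to compound 3 (within the scatter), the first reading of a single change. For the compounds shown here, at this position and at the one concentration tested, the read-out does not separate these two dihalophenyl groups, something the earlier compounds, which differ in more than one place, could not show. No evidence on the cause of this result is at hand.

Going by these compounds, whether an aminophenyl or a carboxyphenyl group on the same carbonyl carbon would give a step beyond the scatter remains open. On these data alone, it is also open whether the same exchange would give a similar step on the core of compound 1, or at other concentrations.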